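A few compounds are considered here, and "the series" means these few. Any claim that something is new, unique, unknown or untested is made for them only; others in the source may bear on it.

Compound 1 `Cc1ccc(-c2csc(N/N=C/c3ccc(Cl)cc3Cl)n2)cc1` was tested in a functional assay, read by spectrophotometry, with a stated time of 15 min, tested at 60 ug/mL (on this read-out higher numbers stand for a stronger effect at the one concentration tested and lower numbers for a weaker effect), where compound 1 gives 93.3%. Its one companion, compound 2 `Cc1ccc(-c2csc(N/N=C/c3cccs3)n2)cc1`, gives 97.6% in this assay; these two numbers lie within the usual scatter of each other, so compound 1 stands at the lower of the two numbers without any real gap between them. Compound 3 `Clc1ccc(/C=N/Nc2nc(-c3ccccc3)cs2)c(Cl)c1` has not yet been measured. It differs from compound 1 in one place: hydrogen in place of methyl on an aromatic carbon. Among the measured compounds shown here, no pair of measured compounds differs in only one place, so the size of this kind of step is unknown here. Compound 1 already gives 93.3%, close to the top of what this assay can report, leaving little room upward, so the step from compound 1 to compound 3 is expected to be small, a number 3.3 percentage points lower from compound 1 to compound 3 (within the scatter), and not beyond the scatter. Compound 3 is therefore estimated to give 90% in this assay, within a range from 78% to 98%.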

Compound 3, a percentage reported as inhibition, at one concentration (the size of the read-out at that concentration, not a potency): 92.8%
Beside the measured number, compound 3's estimate is 2.8 percentage points below it; the measured number falls inside the stated range.
By their numbers in this assay, from the lowest: compounds 3, 1 and 2 (each within the scatter of the next).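

In this assay, among the compounds shown here, this is the first one-place step that can be read, and 4-methylphenyl to phenyl gives a number 0.5 percentage points lower from compound 1 to compound 3 (within the scatter), so this read-out does not tell the two compounds apart. At this position on the aromatic ring, para to a large group, the methyl is therefore not required for the strong effect seen at the one concentration tested, and hydrogen serves as well there. The data shown offer no explanation for this result.

An amine, a carboxylic acid or a longer chain at the same place could show whether this position tolerates groups other than methyl and hydrogen, and the compounds shown leave that open. They also leave open whether compound 1 and compound 3 differ in potency, since a reading at a single concentration is not a potency.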